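From a dichlorophenoxy group to a fluorobenzylamino group

This account rests on a few compounds, and the source may have more. Where it says the series, first, only, none or still open, it means among the compounds named here.

Compound 1 `Nc1cc(N)c2nc(-c3ccccc3)c(Oc3ccc(Cl)c(Cl)c3)nc2c1` was examined in a functional assay on OVCAR-4 cells (Homo sapiens) for inhibition, read by sulforhodamine B assay, with a stated time of 48 h; a lower number here means that less compound is tolerated, a higher number that more compound is tolerated. In this assay compound 1 gives only a limit, < 100000 nM. Compound 3 `CCOC(=O)[C@H](CCC(=O)O)NC(=O)c1ccc(Oc2nc3cc(N)cc(N)c3nc2-c2ccccc2)cc1` likewise reaches only a limit in this assay, < 100000 nM. Going by the values given here, compound 2 `COc1ccc(CNc2nc3cc(N)cc(N)c3nc2-c2ccccc2)cc1OC` is the one member of the set with a number in this assay, 52500 nM. Compound 1 thus stands at the limit where two of the three values sit (the limit of < 100000 nM in this assay, at which 2 of the 3 values shown sit), and no order between it and compound 2 or compound 3 can be read from the numbers.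

Compound 4 `Nc1cc(N)c2nc(-c3ccccc3)c(NCc3ccc(F)cc3)nc2c1` has not yet been measured. It differs from compound 1 in one place: (4-fluorobenzyl)amino in place of 3,4-dichlorophenoxy on an aromatic carbon next to the ring nitrogen and ortho to a phenyl group. Among the compounds with values here, no step between two measured compounds is available to set a size for this change. Compound 2 also carries a benzylamino group in place of the phenoxy, and in this assay compound 2 gives 52500 nM. Compound 4 is therefore expected to give about 50000 nM, within 15000 nM to 150000 nM. Going by these compounds, the expected step that the limit leaves unreadable from compound 1 to compound 4 starts from a limit, and its size relative to the scatter remains open.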

Compound 4, concentration lethal to 50% of the cells: 60300 nM
Estimate against measurement, compound 4: 1.2-fold (0.08 log units) below; measured number inside the range.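

In this assay the result gives the first readable step among these compounds, a 1.1-fold higher number from compound 2 to compound 4 (0.06 log units; within the scatter), for 4-fluorophenyl in place of 3,4-dimethoxyphenyl on a saturated chain carbon bound to a nitrogen on an aromatic ring. Compound 2 and compound 4 therefore cannot be told apart in this read-out, so this exchange at the end of the benzylamino group leaves no effect that can be seen beyond the scatter. The step for (4-fluorobenzyl)amino in place of 3,4-dichlorophenoxy cannot be read, because compound 1 gives only a limit: the limit of < 100000 nM in this assay, at which 2 of the 4 values shown sit.

Going by these compounds, how far the 3,4-dichlorophenoxy and (4-fluorobenzyl)amino groups differ at this position therefore stays open. The compounds shown also do not tell whether a longer chain before the aromatic ring, or a carboxylic acid on that ring, would move the number beyond the scatter.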